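This account rests on a few compounds, and the source may have more. Where it says the series, first, only, none or still open, it means among the compounds named here.

Values in a functional assay on MCF7 cells (Homo sapiens) for inhibition, read by colorimetric assay and MTT assay, with a stated time of 72 h; on this read-out higher numbers stand for weaker inhibition and lower numbers for stronger inhibition:
- compound 1 `CCCCOc1ncc(-c2ccccc2OC)n1C` gives 55000 nM
- compound 2 `C=CCCOc1ncc(-c2ccccc2OC)n1C` gives 27000 nM
- compound 3 `C=CCCCCOc1ncc(-c2ccccc2OC)n1C` gives 5000 nM

In this assay compound 3 has the lowest of the three numbers. Compound 4 `C=CCCCCOc1ncc(-c2cc(C(F)(F)F)ccc2OC)n1C` keeps the chain of compound 3 and adds (trifluoromethyl in place of hydrogen on an aromatic carbon), trifluoromethyl in place of hydrogen on an aromatic carbon.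

The measured steps all lie in the chain: a 2.0-fold lower number from compound 1 to compound 2 (0.31 log units; beyond the scatter), a 5.4-fold lower number from compound 2 to compound 3 (0.73 log units; beyond the scatter) and an 11-fold lower number from compound 1 to compound 3 (1.04 log units; beyond the scatter). None of them changes the aromatic ring, so they give no direct guide to this change. A modest step towards a lower number is expected, though no step beyond the scatter remains possible.

The expected step is a 1.7-fold lower number from compound 3 to compound 4 (0.22 log units; within the scatter).

For compound 4 the estimated value is 3000 nM, with an expected range from 800 nM to 10000 nM.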

Compound 4, half-maximal inhibitory concentration: 61000 nM
Beside the measured number, compound 4's estimate is 20-fold (1.31 log units) below it; measured number above the stated range.
By their numbers in this assay, from the lowest: compound 3; then compound 2; then compounds 1 and 4 (each within the scatter of the next).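

In this assay, trifluoromethyl in place of hydrogen on an aromatic carbon para to a methoxy group gives a 12-fold higher number from compound 3 to compound 4 (1.09 log units; beyond the scatter) on the chain of compound 3. The aromatic ring is therefore not a silent part of the series: this position responds strongly, and in the opposite direction to the chain steps. No measurement here accounts for this rise.

From the compounds shown here alone, whether the rise belongs to trifluoromethyl itself or to any group at this carbon stays open; a single fluorine, a methoxy or an amine here would help separate the two. Also open, going by these compounds, is whether the change acts the same way on the shorter chains of compound 1 and compound 2.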